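Swapping Chloro for Trifluoromethyl in a Weak Partial Agonist

The source may report more compounds than this note shows. Statements on the series, on what has been measured and on what is new or still open speak of the compounds shown alone.

Compound 1, `COc1cc2c(cc1N1CCN(C)CC1)N(C(=O)Nc1cccc(Cl)c1Cl)CC2`: 0.6
Compound 2, `COc1cc2c(cc1N1C[C@@H](C)N(C)[C@@H](C)C1)N(C(=O)Nc1cccc(Cl)c1Cl)CC2`: 0.1

For the measured compounds named here, in an assay on isolated protein with 5-hydroxytryptamine receptor 1B (Homo sapiens) as the target (on this read-out higher numbers stand for larger maximal responses and lower numbers for smaller maximal responses), compound 2 gives 0.1, the lowest of the two numbers measured; the one step recorded, a number 0.50 lower from compound 1 to compound 2 (beyond the scatter), concerns a different part of the molecule. Compound 3, `COc1cc2c(cc1N1C[C@@H](C)N(C)[C@@H](C)C1)N(C(=O)Nc1cccc(C(F)(F)F)c1Cl)CC2`, differs from compound 2 by trifluoromethyl in place of chloro on an aromatic carbon. Going by the values given here, no measured step touches this part of the structure, so nothing shows whether a change here moves the response. With compound 2 as the only anchor, the change is expected to give no change at the digits printed from compound 2 to compound 3 (within the scatter). Compound 3 is therefore estimated at 0.1, in a range from 0 to 0.3.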

Compound 3, intrinsic activity: the largest response reached, as a fraction of the reference agonist's: 0
Estimate against measurement, compound 3: 0.10 above, and the stated range covers the measured number.
By their numbers in this assay, from the lowest: compounds 3 and 2 (each within the scatter of the next); then compound 1.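

In this assay, this first measured change on the 2,3-dichlorophenyl group gives a number 0.10 lower from compound 2 to compound 3 (within the scatter): with the 3,4,5-trimethylpiperazin-1-yl group in place, trifluoromethyl can stand in for chloro on this aromatic carbon without a shift beyond the scatter. No measurement shown gives a reason for this outcome.

Compound 2 already gives only 0.1, so this pair cannot show whether the same swap would matter alongside the 4-methylpiperazin-1-yl group of compound 1. As far as these compounds go, whether a nitrile or an amine at this place would behave the same way remains open.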